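A few compounds are considered here, and "the series" means these few. Any claim that something is new, unique, unknown or untested is made for them only; others in the source may bear on it.

Compound 1 `CCCOC(=O)N1CCC(Oc2ncnc3c2CCN3c2ccc(S(C)(=O)=O)cc2F)CC1` gives 79.4 nM in a functional assay on CHO-K1 cells for agonist activity at Glucose-dependent insulinotropic receptor (Homo sapiens), read by a luciferase reporter, with a stated time of 5 h; on this read-out higher numbers stand for an effect only at larger amounts of compound and lower numbers for an effect already at smaller amounts; compound 2 `CS(=O)(=O)c1ccc(N2CCc3c(OC4CCN(C5=NCCCN5)CC4)ncnc32)c(F)c1` gives 2000 nM; compound 3 `CC(C)OC(=O)N1CCC(Oc2ncnc3c2CCN3c2ccc(C#N)cn2)CC1` gives 794 nM.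

Compound 3 stands second highest of the three numbers in this assay, nearest to compound 2 and furthest from compound 1. Compound 4 `CC(C)OC(=O)N1CCC(Oc2ncnc3c2CCN3c2ccc([S+]([O-])N(C)C)cc2)CC1` differs from compound 3 by a group of 11 heavy atoms (8 carbon, 1 nitrogen, 1 oxygen, 1 sulfur; one six-membered aromatic ring of carbon only) in place of a group of 8 heavy atoms (6 carbon, 2 nitrogen; one six-membered aromatic ring with 1 hetero atom), on a nitrogen on an aromatic ring in a ring. Going by the values given here, the one measured step, a 25-fold higher number from compound 1 to compound 2 (1.40 log units; beyond the scatter), concerns the amine nitrogen in a ring and not this position, so it does not bear on the change. Compound 1 and compound 3 differ in two places, and their two values show that compound 1, whose aromatic ring carries a sulfur-bearing group, gives the lower number. On this basis compound 4 is expected to give 250 nM, with a range from 60 nM to 1000 nM. The expected step is a 3.2-fold lower number from compound 3 to compound 4 (0.50 log units; beyond the scatter).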

Compound 4, half-maximal effective concentration: 501 nM
The estimate for compound 4 lay 2.0-fold (0.30 log units) below the measured number; low and high end bracket the measured number.
By their numbers in this assay, from the lowest: compound 1; then compounds 4 and 3 (each within the scatter of the next); then compound 2.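

In this assay, exchanging 5-cyanopyridin-2-yl for the sulfur-bearing group with an aromatic ring of carbon only, on a nitrogen on an aromatic ring in a ring, gives a 1.6-fold lower number from compound 3 to compound 4 (0.20 log units; within the scatter), so this pair cannot be told apart. Going by these compounds alone, the earlier single step concerned only the amine nitrogen in a ring, so this is the first reading at this position. No measurement given here bears on the reason for this result.

The compounds shown leave open how an amine or a carboxylic acid on that aromatic ring would read at this position.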